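Replacing an Amino Group with Carboxy on the Shared Core

The compounds below may be only part of what the source reports. "The series", "measured", "known", "first", "only" and "open" are said of these compounds alone.

Three compounds share one core and differ only in the group on one aromatic carbon of it. Compound 1 `CCCCCCc1c(F)c(N)c2c(=O)cc(-c3ccc(N)c(F)c3)oc2c1F` carries a hexyl there. In a functional assay on MCF7 cells (Homo sapiens) for cytotoxicity, read by neutral red uptake, with a stated time of 3 days (a higher number here means a weaker inhibitor, a lower number a stronger inhibitor), compound 1 gives only a limit, > 10000 nM, which is the limit of > 10000 nM in this assay, at which 1 of the 3 values shown sits. Compound 2 `[N-]=[N+]=Nc1c(F)c(N)c2c(=O)cc(-c3ccc(N)c(F)c3)oc2c1F` carries an azido there, and in this assay compound 2 gives 460 nM. Compound 3 `Nc1ccc(-c2cc(=O)c3c(N)c(F)c(N)c(F)c3o2)cc1F` carries an amino there, and in this assay compound 3 gives 7.7 nM, the lowest of the two numbers, with compound 2 as the nearest. All the steps are large: an at least 21-fold lower number from compound 1 to compound 2 (1.33 log units; beyond the scatter), an at least 1200-fold lower number from compound 1 to compound 3 (3.11 log units; beyond the scatter) and a 60-fold lower number from compound 2 to compound 3 (1.78 log units; beyond the scatter). Compound 4 `Nc1ccc(-c2cc(=O)c3c(N)c(F)c(C(=O)O)c(F)c3o2)cc1F` has not been measured; it changes that same carbon once more, (carboxy in place of amino on an aromatic carbon). Every measured step concerns this one carbon, and the amino gave the lowest number while azido and hexyl gave far higher ones, so a weaker compound 4 is expected, with a step of a 39-fold higher number from compound 3 to compound 4 (1.59 log units; beyond the scatter) that is expected to lie beyond the scatter. Compound 4 is estimated at 300 nM in this assay, with a range from 40 nM to 3000 nM.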

Compound 4, half-maximal inhibitory concentration: > 10000 nM
Compound 4: only a limit was reported; the forecaster's own chance of this, stated with the estimate: 10%; middle value at least 33-fold (1.52 log units) from the limit.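

Amino and carboxy have the same counted hydrogen-bond donors and acceptors and no net charge, yet this change gives an at least 1200-fold higher number from compound 3 to compound 4 (3.11 log units; beyond the scatter), so those counts alone do not decide the outcome at this carbon. Carboxy also compares poorly with azido, with an at least 21-fold higher number from compound 2 to compound 4 (1.33 log units; beyond the scatter). Compound 4 gives only a limit, and the step between compound 1 and compound 4 cannot be read, so these two cannot be ranked against each other: the limit of > 10000 nM in this assay, at which 2 of the 4 values shown sit.

The compounds shown leave open how narrow the preference for amino is, since a methylamino or hydroxy group on this carbon could show whether a close relative of amino keeps a low number. A primary amide or a methyl ester in place of carboxy could show whether the loss follows the carbonyl or the free acid.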